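This account rests on a few compounds, and the source may have more. Where it says the series, first, only, none or still open, it means among the compounds named here.

Compound 1 `COC1=C(OC)[C@H](O)[C@H](C/C=C(\C)CC/C=C(\C)C[C@@H]2C[C@@H](C)C(=O)O2)[C@@H](C)C1=O`; compound 2 `COC1=C(OC)[C@H](OC(C)=O)[C@H](C/C=C(\C)CC/C=C(\C)C[C@H](O)C=C(C)C)[C@@H](C)C1=O`; compound 3 `COC1=C(OC)[C@H](O)[C@H](C/C=C(\C)CC/C=C(\C)CC/C=C(\C)CO)[C@@H](C)C1=O`; compound 4 `COC1=C(OC)[C@H](O)[C@H](C/C=C(\C)CC/C=C(\C)C[C@H](O)C=C(C)C)[C@@H](C)C1=O`, not yet measured.

In a functional assay on PC-3 cells (Homo sapiens) for inhibition, read by sulforhodamine B assay, with a stated time of 48 h (on this read-out lower numbers stand for stronger inhibition of growth and higher numbers for weaker inhibition of growth), compound 1 gives > 30000 nM, which is a limit of the assay rather than a number. Compound 2 likewise gives only a limit, > 30000 nM. Compound 3 also sits at a limit, > 30000 nM. Going by the values given here, with the limit of > 30000 nM in this assay, at which 3 of the 3 values shown sit, no value shown is a readable number, so the single measured step that ends at compound 3, a step that the two limits leave unreadable from compound 1 to compound 3, has no readable size. Compound 4 differs from compound 3 by 1-hydroxy-3-methylbut-2-en-1-yl in place of 3-(hydroxymethyl)but-2-en-1-yl on a saturated chain carbon bound to a double-bonded chain carbon. Compound 2 already carries the 1-hydroxy-3-methylbut-2-en-1-yl group and stays at the limit. The step that the limit leaves unreadable from compound 3 to compound 4 is therefore expected to be none beyond the scatter. Compound 4 is estimated at 40000 nM, between 15000 nM and 120000 nM, most likely reported again only as a limit.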

Compound 4, concentration for 50% growth inhibition: > 30000 nM
Compound 4: a limit, no number (the forecaster's own chance of this, stated with the estimate: 80%); the middle value is on the limit's open side.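

No step from compound 1, compound 2 or compound 3 to compound 4 can be read, because each gives a limit rather than a number: the limit of > 30000 nM in this assay, at which 4 of the 4 values shown sit.

As far as these compounds go, whether any of these structural changes alters growth inhibition remains open.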